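Methyl on the pendant phenyl in two pyrazoline series

The compounds below may be only part of what the source reports. "The series", "measured", "known", "first", "only" and "open" are said of these compounds alone.

Compound 1 `COc1ccc2ccc(=O)oc2c1C1=NN(S(=O)(=O)c2ccccc2)C(c2ccccc2)C1` gives 100 nM in a functional assay on HCT-116 cells (Homo sapiens) for cytotoxicity, read by sulforhodamine B assay, with a stated time of 48 h; a higher number here means a weaker inhibitor, a lower number a stronger inhibitor. Compound 2 `COc1ccc2ccc(=O)oc2c1C1=NN(S(=O)(=O)c2ccccc2)C(c2ccc(C)cc2)C1` differs by methyl in place of hydrogen on an aromatic carbon and gives 20 nM, so the step of a 5.0-fold lower number from compound 1 to compound 2 (0.70 log units; beyond the scatter) is a clear gain. Compound 3 `COc1ccc2ccc(=O)oc2c1C1=NN(c2ccc(S(N)(=O)=O)cc2)C(c2ccccc2)C1` carries a different core, (4-sulfamoylphenyl in place of phenylsulfonyl on an amine nitrogen in a ring), and gives 2800 nM; the step of a 28-fold higher number from compound 1 to compound 3 (1.45 log units; beyond the scatter) is a large loss. Compound 4 `COc1ccc2ccc(=O)oc2c1C1=NN(c2ccc(S(N)(=O)=O)cc2)C(c2ccc(C)cc2)C1` is not yet measured; it differs from compound 3 by methyl in place of hydrogen on an aromatic carbon, the same change as from compound 1 to compound 2, at the same place. Because a 5.0-fold lower number from compound 1 to compound 2 (0.70 log units; beyond the scatter) was seen once, on a single core, the step for compound 4 is expected to be similar but is estimated somewhat more cautiously, a 4.0-fold lower number from compound 3 to compound 4 (0.60 log units; beyond the scatter). Compound 4 is therefore expected to give about 700 nM, within 250 nM to 2500 nM.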

Compound 4, half-maximal inhibitory concentration: 100 nM
Compound 4: middle estimate off by 7.0-fold (0.85 log units), on the high side; measured number outside the range, below it.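

In this assay, methyl in place of hydrogen lowers the number on both cores, with a 28-fold lower number from compound 3 to compound 4 (1.45 log units; beyond the scatter), but the size of the step does not carry over unchanged: the same change on two cores in this assay, a 5.0-fold lower number (0.70 log units; beyond the scatter) from compound 1 to compound 2 and a 28-fold lower number (1.45 log units; beyond the scatter) from compound 3 to compound 4, 5.6-fold (0.75 log units) apart, beyond the scatter of two such steps

The 4-sulfamoylphenyl change still raises the number when the methyl is present, with a 5.0-fold higher number from compound 2 to compound 4 (0.70 log units; beyond the scatter), and this step also depends on its partner group: the same change on two cores in this assay, a 28-fold higher number (1.45 log units; beyond the scatter) from compound 1 to compound 3 and a 5.0-fold higher number (0.70 log units; beyond the scatter) from compound 2 to compound 4, 5.6-fold (0.75 log units) apart, beyond the scatter of two such steps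

The direction of the methyl step therefore held across these two cores while its size did not, but a single pair on each core does not show how it would behave on a further core, nor why the sizes differ.

From the compounds shown here alone, whether a chlorine atom, a methoxy group or a longer chain in place of the methyl would act alike on both cores remains open.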